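Phenyl for Chlorobenzyl on an Amide Nitrogen

The source may hold more compounds than are shown below. What is called first, only, known or untested is meant among the compounds shown, and "the series" means these compounds.

Compound 2 `C=CC1=C(C(=O)NCc2ccc(Cl)cc2)C(c2ccc(OC)cc2)OC1` was tested in a functional assay on A549 cells (Homo sapiens) for cytotoxicity, read by MTT assay, with a stated time of 24 h (a lower number here means a stronger inhibitor, a higher number a weaker inhibitor), where compound 2 gives > 100000 nM, a limit of the assay rather than a number. Its neighbours fare the same way. Compound 1 `C=CC1=C(C(=O)NCc2ccc(Cl)cc2)C(c2ccc(OC)c(OC)c2)OC1` gives > 100000 nM in this assay, also a limit. Compound 3 `C=CC1=C(C(=O)NCCCCC)C(c2ccc(F)cc2)OC1` gives > 100000 nM in this assay, again a limit. Going by the values given here, the only step between compounds that differ in one place is a step that the two limits leave unreadable from compound 1 to compound 2, and its size is not readable since every value sits at the limit of > 100000 nM in this assay, at which 3 of the 3 values shown sit.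

Compound 4 `C=CC1=C(C(=O)Nc2ccccc2)C(c2ccc(OC)cc2)OC1` differs from compound 2 by phenyl in place of 4-chlorobenzyl on an amide-type nitrogen. Among the compounds with values here, no measured step bears on this change, and the one step that exists cannot be sized. Compound 4 is therefore expected to sit at 100000 nM in this assay, within a range of 30000 nM to 300000 nM. The expected step of a number no higher from compound 2 to compound 4 (the limit leaves the size open) is none beyond the scatter, and most likely only another limit will be reported.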

Compound 4, half-maximal inhibitory concentration: > 100000 nM
Compound 4: no number, only a limit; the forecaster's own chance of this, stated with the estimate: 85%; the middle value sits exactly at the limit.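

No size can be read for the change from compound 2 to compound 4, since both results are limits of the assay rather than numbers: the limit of > 100000 nM in this assay, at which 4 of the 4 values shown sit. The compounds shown leave open whether any of them gives a measurable value in this assay, and so whether swapping 4-chlorobenzyl for phenyl matters there.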